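The compounds below may be only part of what the source reports. "The series", "measured", "known", "first", "only" and "open" are said of these compounds alone.

In a functional assay on PC-3 cells (Homo sapiens) for inhibition, read by sulforhodamine B assay, with a stated time of 48 h, tested at 0.1 uM (on this read-out lower numbers stand for a stronger effect and higher numbers for a weaker effect at the one concentration tested), compound 2 `COc1cc(Cl)cc(-c2nn(-c3cccc(NC(=O)Nc4ccc(Cl)c(Cl)c4)c3)cc2-c2ccncc2)c1` gives 98%, and compound 1 `COc1cc(Cl)cc(-c2nn(-c3cccc(NC(=O)Nc4cc(C(F)(F)F)cc(C(F)(F)F)c4)c3)cc2-c2ccncc2)c1` gives 91%. Among the measured compounds shown here, these are the only two numbers so far, and compound 2 sits within the usual scatter of compound 1, so neither can be said to act more strongly than the other; at this single concentration both leave most of the cell growth untouched. Compound 3 `COc1cc(Cl)cc(-c2nn(-c3cccc(NC(=O)Nc4cccc(C(F)(F)F)c4)c3)cc2-c2ccncc2)c1` has not yet been measured. It differs from compound 2 in one place: 3-(trifluoromethyl)phenyl in place of 3,4-dichlorophenyl on an amide-type nitrogen. For the measured compounds named here, no measured pair shows the size of such a swap, but compound 1, which carries two trifluoromethyl groups on the same ring, gives 91%, close to compound 2, so the change is expected to be a number 4 percentage points lower from compound 2 to compound 3 (within the scatter), a step not beyond the scatter. Compound 3 is therefore estimated at 94%, with a likely range from 82% to 103%.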

Compound 3, a percentage reported as activity, at one concentration (the size of the read-out at that concentration, not a potency): 57%
Estimate against measurement, compound 3: 37 percentage points above; the measured number lies below the stated range.
By their numbers in this assay, from the lowest: compound 3; then compounds 1 and 2 (each within the scatter of the next).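

In this assay, the group on the amide-type nitrogen proves able to change the result strongly: 3-(trifluoromethyl)phenyl in place of 3,4-dichlorophenyl gives a clearly stronger effect (a number 41 percentage points lower from compound 2 to compound 3 (beyond the scatter)). Hydrogen in place of trifluoromethyl on an aromatic carbon of that ring gives a step of similar size (a number 34 percentage points lower from compound 1 to compound 3 (beyond the scatter)), so the two earlier compounds, whose close values suggested little sensitivity here, gave no hint of this change. Nothing available explains why these swaps have such an effect.

From the compounds shown here alone, it remains open whether the stronger effect depends on the trifluoromethyl group itself or would persist with an amine or a carboxylic acid on the ring. The compounds shown also leave open how other swaps on this ring would behave when the rest of the molecule stays the same.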